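The source may hold more compounds than are shown below. What is called first, only, known or untested is meant among the compounds shown, and "the series" means these compounds.

Compound 3 `COc1ccc(/C=C\c2cc(OC)c(OC)c(OC)c2)cc1OCc1ccc(CNCCNC(C)=O)cc1` gives 6100 nM in a functional assay on HepG2 cells (Homo sapiens) for antiproliferative activity, read by CCK-8 assay, with a stated time of 48 h; on this read-out higher numbers stand for weaker inhibition and lower numbers for stronger inhibition. Among the two numbers recorded it stands lowest, but its nearest neighbour, compound 1 `COc1ccc(/C=C\c2cc(OC)c(OC)c(OC)c2)cc1OCc1ccc(CN2CC[C@H](C(=O)O)C2)cc1` with 6400 nM, sits so close that a 1.0-fold lower number from compound 1 to compound 3 (0.02 log units; within the scatter) carries no order between them. Compound 2 `COc1ccc(/C=C\c2cc(OC)c(OC)c(OC)c2)cc1OCc1ccc(CN2C[C@H](O)C[C@@H]2C(=O)O)cc1` is recorded only as a limit, > 10000 nM, in this assay; the limit of > 10000 nM in this assay, at which 1 of the 3 values shown sits, marks that edge. Against that limit the steps read an at least 1.5-fold higher number from compound 1 to compound 2 (0.19 log units; that floor lies within the scatter) and an at least 1.6-fold lower number from compound 2 to compound 3 (0.21 log units; that floor lies within the scatter), both floors that lie inside the usual scatter.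

Compound 4 `COc1ccc(/C=C\c2cc(OC)c(OC)c(OC)c2)cc1OCc1ccc(CNCCN(C)C)cc1` keeps the shared core and the benzyl-linked amine and changes only the tail: dimethylamino in place of acetamido on a saturated chain carbon, two bonds along the chain from an amine nitrogen. Every measured step here rearranges the same amine side of the molecule, and none of them moved the number beyond the scatter, so compound 3 to compound 4 is expected to behave alike, with a 1.0-fold lower number from compound 3 to compound 4 (0.01 log units; within the scatter) as the estimated step and no direction claimed. Compound 4 is therefore estimated at 6000 nM, with a range from 2500 nM to 15000 nM.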

Compound 4, half-maximal inhibitory concentration: 4400 nM
Compound 4: middle estimate off by 1.4-fold (0.13 log units), on the high side, and the stated range covers the measured number.
By their numbers in this assay, from the lowest: compounds 4, 3 and 1 (each within the scatter of the next). At a limit, above all of these: compound 2.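

In this assay, dimethylamino in place of acetamido on this saturated chain carbon, two bonds along the chain from an amine nitrogen, gives no readable change (a 1.4-fold lower number from compound 3 to compound 4 (0.14 log units; within the scatter)). Among these compounds, the (2-(dimethylamino)ethyl)amino group in place of 3-carboxypyrrolidin-1-yl also stays within the scatter (a 1.5-fold lower number from compound 1 to compound 4 (0.16 log units; within the scatter)), while the swap for 2-carboxy-4-hydroxypyrrolidin-1-yl gives the first step here that clears it (an at least 2.2-fold lower number from compound 2 to compound 4 (0.35 log units; beyond the scatter)). That step is only a floor, and compound 2 stands at a limit, not a number: the limit of > 10000 nM in this assay, at which 1 of the 4 values shown sits.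

The compounds shown leave open whether a primary amine, a carboxylic acid or a longer chain at this position would move the number beyond the scatter. The measured values of compounds 1, 3 and 4 give no order among these tails.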